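Swapping a thiophene for a methylindole on an acylated amide

The compounds below may be only part of what the source reports. "The series", "measured", "known", "first", "only" and "open" are said of these compounds alone.

Compounds measured so far:
- compound 1 `CCCCCCCCCCCCCCCCCCNC(=O)[C@@H](N)[C@@H](C)O`, 44500 nM
- compound 2 `CCCCCCCCCCCCCCCCCCNC(=O)[C@@H](NC(=O)c1cccs1)[C@@H](C)O`, 92000 nM

In a functional assay on HepG2 cells (Homo sapiens) for cytotoxicity, read by MTT assay, with a stated time of 48 h (on this read-out lower numbers stand for stronger inhibition and higher numbers for weaker inhibition), compound 1 gives 44500 nM. Compound 2 `CCCCCCCCCCCCCCCCCCNC(=O)[C@@H](NC(=O)c1cccs1)[C@@H](C)O` is the same molecule with an acyl group on its amine nitrogen, and in this assay compound 2 gives 92000 nM, the higher of the two numbers: a 2.1-fold higher number from compound 1 to compound 2 (0.32 log units; beyond the scatter).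

Compound 3 `CCCCCCCCCCCCCCCCCCNC(=O)[C@@H](NC(=O)c1cc2ccccc2n1C)[C@@H](C)O` keeps that acyl group but changes the ring on it: 1-methyl-1H-indol-2-yl in place of thiophen-2-yl on a carbonyl carbon. Among the measured compounds shown here, no measured step exchanges one ring for another on this carbonyl; the only known step, a 2.1-fold higher number from compound 1 to compound 2 (0.32 log units; beyond the scatter), concerns adding the acyl group, not what ring it carries. It therefore offers no direction for the new change. For compound 3 the step of a 1.2-fold lower number from compound 2 to compound 3 (0.06 log units; within the scatter) is expected to stay within the scatter. Compound 3 is estimated at 80000 nM, with a range from 30000 nM to 200000 nM.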

Compound 3, half-maximal inhibitory concentration: > 200000 nM
Compound 3: only a limit was reported; the forecaster's own chance of this, stated with the estimate: 25%; middle value at least 2.5-fold (0.39 log units) away from the limit.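

In this assay, the ring carried on this carbonyl turns out to matter: 1-methyl-1H-indol-2-yl in place of thiophen-2-yl gives an at least 2.1-fold higher number from compound 2 to compound 3 (0.33 log units; beyond the scatter). Until now, the effect of an acyl group on the amine nitrogen rested on compound 2 alone, and a second acyl group now moves the same way, with an at least 4.4-fold higher number from compound 1 to compound 3 (0.65 log units; beyond the scatter). Compound 3 has only a limit of the assay, not a number, so both steps give only a minimum size: the limit of > 200000 nM in this assay, at which 1 of the 3 values shown sits.

The compounds shown leave open whether a simple acetyl group, with no ring, would also raise the number relative to compound 1. They also leave open whether an unmethylated indol-2-yl group would behave like 1-methyl-1H-indol-2-yl, and what a shorter chain in place of the long one would do.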